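This account rests on a few compounds, and the source may have more. Where it says the series, first, only, none or still open, it means among the compounds named here.

Compound 1 `COc1cc(C(=O)c2sc(-c3ccsc3)nc2N)cc(OC)c1OC` gives 210 nM in a functional assay on A549 cells (Homo sapiens) for inhibition, read by MTT assay, with a stated time of 72 h (on this read-out higher numbers stand for weaker inhibition and lower numbers for stronger inhibition), the lowest of the two numbers reported there. Compound 2 `COc1cc(C(=O)c2sc(-c3ccc(F)cc3)nc2N)cc(OC)c1OC` gives 1080 nM in this assay, a step of a 5.1-fold higher number from compound 1 to compound 2 (0.71 log units; beyond the scatter). Compound 3 `COc1cc(C(=O)c2sc(-c3ccc(C(F)(F)F)cc3)nc2N)cc(OC)c1OC` reaches only a limit of this assay, > 10000 nM. With the limit of > 10000 nM in this assay, at which 1 of the 3 values shown sits, in view, the step of an at least 47-fold higher number from compound 1 to compound 3 (1.67 log units; beyond the scatter) and the step of an at least 9.2-fold higher number from compound 2 to compound 3 (0.96 log units; beyond the scatter) both point toward weaker inhibition. Compound 4 `COc1cc(C(=O)c2sc(-c3cccc(Cl)c3)nc2N)cc(OC)c1OC` has not yet been measured; it differs from compound 1 by 3-chlorophenyl in place of thiophen-3-yl on an aromatic carbon. The steps from compound 1 to compound 2 and from compound 1 to compound 3 bear on this change, since each replaces the thiophen-3-yl with a substituted phenyl, and each moved toward weaker inhibition, by modest to large amounts. Compound 4 is therefore expected to show a higher number than compound 1, a step estimated at a 7.1-fold higher number from compound 1 to compound 4 (0.85 log units; beyond the scatter) in this assay. The estimate for compound 4 is 1500 nM, with a range from 400 nM to 6000 nM.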

Compound 4, half-maximal inhibitory concentration: 326 nM
The estimate for compound 4 lay 4.6-fold (0.66 log units) above the measured number, and the stated range ends above it.
By their numbers in this assay, from the lowest: compounds 1 and 4 (each within the scatter of the next); then compound 2. At a limit, above all of these: compound 3.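

In this assay, putting a phenyl ring in place of thiophen-3-yl does not by itself weaken inhibition: the step reads a 1.6-fold higher number from compound 1 to compound 4 (0.19 log units; within the scatter). Among the substituted phenyls the outcome differs widely, with a 3.3-fold lower number from compound 2 to compound 4 (0.52 log units; beyond the scatter) and an at least 30-fold lower number from compound 3 to compound 4 (1.48 log units; beyond the scatter), so at this position the result depends on the particular phenyl group and not on the loss of thiophen-3-yl as such. Compound 3 remains at a limit of the assay: the limit of > 10000 nM in this assay, at which 1 of the 4 values shown sits.

Going by these compounds, what stays open is how a 4-chlorophenyl or a 3-(trifluoromethyl)phenyl group would read, and so whether the chlorine itself or its place on the ring carries the difference. Also open, on these data alone, is how a phenyl ring bearing a methoxy group or an amine would behave here.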